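The source may report more compounds than this note shows. Statements on the series, on what has been measured and on what is new or still open speak of the compounds shown alone.

Measured so far:
- compound 1 `CCN(CC)C(=S)SCC1=CCOC1=O`: 136000 nM
- compound 2 `O=C1CC2(CO1)CSC(=S)N2c1ccccc1`: 128000 nM

In a functional assay on EC9706 cells (Homo sapiens) for antiproliferative activity, read by MTT assay, with a stated time of 72 h (on this read-out lower numbers stand for stronger inhibition and higher numbers for weaker inhibition), compound 1 gives 136000 nM and compound 2 gives 128000 nM. These two values lie within the scatter of each other, so compound 1 stands level with compound 2. Next is compound 3 `O=C1OCC=C1CSC(=S)NC1CC1`, with cyclopropylamino in place of diethylamino on a thiocarbonyl carbon. Among the compounds with values here, no measured pair sizes this change, so the expectation is loose: a moderate step towards stronger inhibition. The expected step is a 2.3-fold lower number from compound 1 to compound 3 (0.36 log units; beyond the scatter). For compound 3 the estimated value is 60000 nM, with an expected range of 15000 nM to 200000 nM.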

Compound 3, half-maximal inhibitory concentration: 53600 nM
Compound 3: middle estimate off by 1.1-fold (0.05 log units), on the high side; the range from low to high includes it.
By their numbers in this assay, from the lowest: compound 3; then compounds 2 and 1 (each within the scatter of the next).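

In this assay, cyclopropylamino in place of diethylamino on a thiocarbonyl carbon gives a 2.5-fold lower number from compound 1 to compound 3 (0.40 log units; beyond the scatter), so the group at this position does change the read-out, by a modest step beyond the scatter. The change brings in a ring and a hydrogen-bond donor together, and this single pair cannot separate the two. No measurement at hand accounts for the step.

Going by these compounds, whether the ring or the donor matters stays open. Isopropylamino or cyclobutylamino at the same position would test this.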